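The source may report more compounds than this note shows. Statements on the series, on what has been measured and on what is new or still open speak of the compounds shown alone.

Compounds measured in a functional assay on MGC-803 cells (Homo sapiens) for inhibition, read by MTT assay, with a stated time of 72 h; on this read-out higher numbers stand for weaker inhibition and lower numbers for stronger inhibition:
- Compound 1 `C=CC(=O)Nc1cccc(NC(=O)CSc2nc(Nc3ccccc3C)c3ccccc3n2)c1`: 30200 nM
- Compound 2 `C=CC(=O)Nc1cccc(NC(=O)CSc2nc(Nc3ccc(Cl)cc3)c3ccccc3n2)c1`: 14300 nM

Among the measured compounds shown here, compound 2 has the lower of these two numbers; the only step between them, a 2.1-fold lower number from compound 1 to compound 2 (0.32 log units; beyond the scatter), moved the number modestly downward. Compound 3 `C=CC(=O)Nc1cccc(NC(=O)CSc2nc(Nc3ccc(CC)cc3)c3ccccc3n2)c1` differs from compound 2 by ethyl in place of chloro on an aromatic carbon. For the measured compounds named here, no measured step swaps one group for another at this same place, so the change from compound 1 to compound 2 bears on it only loosely. The expected step in this assay is therefore small, a 1.1-fold higher number from compound 2 to compound 3 (0.05 log units; within the scatter), with no clear direction beyond the scatter. Compound 3 is estimated at 16000 nM, within a range of 6000 nM to 40000 nM.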

Compound 3, half-maximal inhibitory concentration: 8010 nM
Compound 3: the middle estimate sits 2.0-fold (0.30 log units) above what was measured; low and high end bracket the measured number.
By their numbers in this assay, from the lowest: compounds 3 and 2 (each within the scatter of the next); then compound 1.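

In this assay, ethyl in place of chloro gives a 1.8-fold lower number from compound 2 to compound 3 (0.25 log units; within the scatter), so the read-out does not separate these two groups at this carbon, para to a large group. The step of a 3.8-fold lower number from compound 1 to compound 3 (0.58 log units; beyond the scatter) shows that 4-ethylphenyl, like 4-chlorophenyl, gives a lower number than 2-methylphenyl by more than the scatter. Nothing available explains these results. On these data alone, whether an amine, a carboxylic acid or a longer chain such as butyl at this carbon would give a similar number remains open. So does whether a methyl group at this same carbon would match the 4-ethylphenyl result.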